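A Methyl on the Cyclohexyl Ring of Compound 2

This account rests on a few compounds, and the source may have more. Where it says the series, first, only, none or still open, it means among the compounds named here.

Compound 2 `CC(C(=O)NCc1ccc(C(F)(F)F)nc1NC1CCCCC1)c1ccc(NS(C)(=O)=O)c(F)c1` gives 260 nM in a functional assay on CHO-K1 cells for antagonist activity at transient receptor potential cation channel subfamily V member 1 (Homo sapiens), read by FLIPR (on this read-out lower numbers stand for stronger inhibition and higher numbers for weaker inhibition), and compound 1 `CCCCNc1nc(C(F)(F)F)ccc1CNC(=O)C(C)c1ccc(NS(C)(=O)=O)c(F)c1` gives 293 nM. Within the data shown here, the only measured step, a 1.1-fold lower number from compound 1 to compound 2 (0.05 log units; within the scatter), stays within the scatter, so the two compounds are not ranked. Compound 3 `CC1CCC(Nc2nc(C(F)(F)F)ccc2CNC(=O)C(C)c2ccc(NS(C)(=O)=O)c(F)c2)CC1` differs from compound 2 by methyl in place of hydrogen on a saturated ring carbon. Among the measured compounds shown here, no measured step touches the saturated ring itself; the one step known exchanged the whole group on the ring nitrogen without moving the number beyond the scatter. Compound 3 is therefore expected to show no step beyond the scatter in this assay, a 1.1-fold lower number from compound 2 to compound 3 (0.03 log units; within the scatter). Compound 3 is estimated at 240 nM, within 80 nM to 720 nM.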

Compound 3, half-maximal inhibitory concentration: 1130 nM
Compound 3: middle estimate off by 4.7-fold (0.67 log units), on the low side; the measured number lies above the stated range.
By their numbers in this assay, from the lowest: compounds 2 and 1 (each within the scatter of the next); then compound 3.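

In this assay, the saturated ring tolerates less than the earlier exchange of whole groups suggested: a single methyl on a saturated ring carbon, three ring bonds from the ring atom that bears a large group, moves the number beyond the scatter (a 4.3-fold higher number from compound 2 to compound 3 (0.64 log units; beyond the scatter)). Measured against butyl, 4-methylcyclohexyl likewise gives a number beyond the scatter (a 3.9-fold higher number from compound 1 to compound 3 (0.59 log units; beyond the scatter)). Nothing shown gives a reason for this shift.

As far as these compounds go, whether the loss follows from methyl alone remains open. A hydroxyl or an ethyl on this carbon, or a cyclopentyl in place of the cyclohexyl, could show whether other groups behave alike.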